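This account rests on a few compounds, and the source may have more. Where it says the series, first, only, none or still open, it means among the compounds named here.

Measured in an ADME assay on MT4 cells (Homo sapiens) for cytotoxicity, read by MTT assay, with a stated time of 96 h; on this read-out lower numbers stand for higher toxicity in this test and higher numbers for lower toxicity in this test:
- Compound 1 `C/C(=N\O)c1ccc2[nH]c(-c3ccc(Cl)cc3)nc2c1`: 20000 nM
- Compound 2 `C/C(=N\NC(N)=S)c1ccc2[nH]c(-c3ccc(Cl)cc3)nc2c1`: 2000 nM
- Compound 3 `C/C(=N\NC(N)=S)c1ccc2[nH]c(-c3ccc(C(F)(F)F)cc3)nc2c1`: 2000 nM

Compound 2 shares the lowest number of the three with compound 3, and compound 1 stands well above them. The next compound, compound 4 `C/C(=N\NC(N)=S)c1ccc2[nH]c(C3CCCCC3)nc2c1`, differs from compound 2 in one place: cyclohexyl in place of 4-chlorophenyl on an aromatic carbon. In short, cyclohexyl stands in place of 4-chlorophenyl on an aromatic carbon.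

For the measured compounds named here, no measured pair makes this exact change. The closest evidence is no change at the digits printed from compound 2 to compound 3 (within the scatter), where trifluoromethyl replaces chloro on that same aromatic ring and the number stays within the scatter. The larger 10-fold lower number from compound 1 to compound 2 (1.00 log units; beyond the scatter) is a change on the double-bonded nitrogen. Compound 4 leaves that nitrogen as it is in compound 2, so this step says little here. Replacing the whole ring is a bigger change than compound 3 tests, so the range stays wide, but no step beyond the scatter is expected. The expected step is a 1.5-fold higher number from compound 2 to compound 4 (0.18 log units; within the scatter). For compound 4 the estimate is 3000 nM, with an expected range of 800 nM to 10000 nM.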

Compound 4, half-maximal cytotoxic concentration: 48000 nM
Beside the measured number, compound 4's estimate is 16-fold (1.20 log units) below it, outside the stated range (above it).
By their numbers in this assay, from the lowest: compounds 2 and 3 (each within the scatter of the next); then compound 1; then compound 4.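

In this assay the group on the aromatic carbon between two ring nitrogen atoms proves able to move the number a long way: cyclohexyl in place of 4-chlorophenyl gives a 24-fold higher number from compound 2 to compound 4 (1.38 log units; beyond the scatter) and a higher number here stands for lower toxicity in this test. The earlier evidence on this group was no change at the digits printed from compound 2 to compound 3 (within the scatter) and that swap kept the aromatic ring in place, so only replacing the whole ring shows how much this position can matter. Nothing available explains the size of this step.

This one change removes both the aromatic ring and the chloro group, so the two cannot be told apart. Plain phenyl, a smaller group such as methyl, and a phenyl ring carrying an amine all remain open at this position.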